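Phenyl in place of a pyridine ring on the shared core

A few compounds are considered here, and "the series" means these few. Any claim that something is new, unique, unknown or untested is made for them only; others in the source may bear on it.

Compound 1 `Cc1cc(C#N)cc(C)c1Oc1nc(Nc2ccc(C#N)cc2)ncc1-c1ccncc1` was tested in an ADME assay on MT4 cells (Homo sapiens) for cytotoxicity, read by MTT assay, with a stated time of 5 days (a higher number here means that more compound is tolerated, a lower number that less compound is tolerated), where compound 1 gives 28000 nM, the lower of the two numbers recorded. Compound 2 `Cc1cc(C)cc(-c2cnc(Nc3ccc(C#N)cc3)nc2Oc2c(C)cc(C#N)cc2C)c1` gives 39000 nM in this assay, and the step of a 1.4-fold higher number from compound 1 to compound 2 (0.14 log units; within the scatter). Compound 3 `Cc1cc(C#N)cc(C)c1Oc1nc(Nc2ccc(C#N)cc2)ncc1-c1cccc2ccccc12` gives only a limit of this assay, > 267000 nM. The steps of an at least 9.5-fold higher number from compound 1 to compound 3 (0.97 log units; beyond the scatter) and an at least 6.8-fold higher number from compound 2 to compound 3 (0.83 log units; beyond the scatter) are the only ones beyond the scatter. Compound 4 `Cc1cc(C#N)cc(C)c1Oc1nc(Nc2ccc(C#N)cc2)ncc1-c1ccccc1` differs from compound 1 in one place: phenyl in place of pyridin-4-yl on an aromatic carbon. Of the measured steps, the change to a 3,5-dimethylphenyl group bears most closely on it and stayed within the scatter, so a small step, if any, is expected. Compound 4 is estimated at 35000 nM, between 15000 nM and 90000 nM. That estimate means a step of a 1.3-fold higher number from compound 1 to compound 4 (0.10 log units; within the scatter), expected to lie within the scatter.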

Compound 4, half-maximal cytotoxic concentration: 31800 nM
For compound 4 the middle estimate is 1.1-fold (0.04 log units) above the measured one; low and high end bracket the measured number.
By their numbers in this assay, from the lowest: compounds 1, 4 and 2 (each within the scatter of the next). At a limit, above all of these: compound 3.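

In this assay, phenyl and pyridin-4-yl cannot be told apart on this aromatic carbon: a 1.1-fold higher number from compound 1 to compound 4 (0.06 log units; within the scatter). Phenyl and 3,5-dimethylphenyl also stay together, a 1.2-fold lower number from compound 2 to compound 4 (0.09 log units; within the scatter), so among these compounds only naphthalen-1-yl stands apart, an at least 8.3-fold lower number from compound 3 to compound 4 (0.92 log units; beyond the scatter). The number for compound 3 is a limit of the assay: the limit of > 267000 nM in this assay, at which 1 of the 4 values shown sits.

The compounds shown leave open where compound 3 would fall as an actual number. They also leave open how this position would read with a non-aromatic group, such as an amine or a carboxylic acid, in place of the aromatic ring.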